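A few compounds are considered here, and "the series" means these few. Any claim that something is new, unique, unknown or untested is made for them only; others in the source may bear on it.

Among the measured compounds shown here, in an ADME assay on tissue (ZR-75-1 cells, Homo sapiens) for pharmacokinetics (a higher number here means that the compound lasts longer, a lower number that the compound disappears faster), compound 2 (`CC(C)[C@H](N)C(=O)OC[C@H]1O[C@@H](n2cc(F)c(=O)[nH]c2=O)C[C@@H]1OC(=O)[C@@H](N)C(C)C`) gives 0.112 h and is the lower of the two compounds measured so far, since compound 1 (`CC(C)[C@H](N)C(=O)OC[C@H]1O[C@@H](n2cc(F)c(=O)[nH]c2=O)C[C@@H]1O`) gives 0.273 h here. Compound 3 (`CC(C)[C@H](N)C(=O)O[C@H]1C[C@H](n2cc(F)c(=O)[nH]c2=O)O[C@@H]1CO`) differs from compound 2 in one place (hydrogen in place of (1-amino-2-methylpropyl)carbonyl on an oxygen on a saturated carbon): hydrogen in place of (1-amino-2-methylpropyl)carbonyl on an oxygen on a saturated carbon, which turns (((1-amino-2-methylpropyl)carbonyl)oxy)methyl into hydroxymethyl. For the measured compounds named here, only one measured step bears on this (a 2.4-fold lower number from compound 1 to compound 2 (0.39 log units; beyond the scatter)). It added the same group at a different oxygen, so it is only an indirect guide. Like compound 1, compound 3 carries that group once, though at the other oxygen. A rise of similar modest size in this assay is therefore expected, and the estimated step is (a 2.4-fold higher number from compound 2 to compound 3 (0.38 log units; beyond the scatter)) with wide uncertainty. The expected value for compound 3 is 0.27 h within an estimated range of 0.13 h to 0.6 h overall.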

Compound 3, half-life: 0.153 h
For compound 3 the middle estimate is 1.8-fold (0.25 log units) above the measured one, within the range that was stated.
By their numbers in this assay, from the lowest: compounds 2, 3 and 1 (each within the scatter of the next, the first and the last beyond it).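

In this assay, putting hydrogen in place of (1-amino-2-methylpropyl)carbonyl at this oxygen gives a 1.4-fold higher number from compound 2 to compound 3 (0.14 log units; within the scatter) and so cannot be told apart from the usual spread of repeated measurements. The same group at the other oxygen gave a 2.4-fold lower number from compound 1 to compound 2 (0.39 log units; beyond the scatter) and this lies beyond the scatter, which suggests that the two oxygens need not count alike, although two single steps are thin support for that. No measured evidence here explains this contrast.

The compounds shown leave open how a compound with hydrogen on both oxygens would behave, as there is no such reference point among them. Going by these compounds, it is also open whether an acetyl group, which lacks the amine, or a longer chain in place of the (1-amino-2-methylpropyl)carbonyl would give a different half-life at either oxygen.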